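A few compounds are considered here, and "the series" means these few. Any claim that something is new, unique, unknown or untested is made for them only; others in the source may bear on it.

Measured so far:
compound 1, `O=C(NCCNS(=O)(=O)c1ccc(-c2ccccc2Oc2ccc(O)c(O)c2)s1)Nc1cc(Cl)cc(Cl)c1`: 12400 nM
compound 2, `O=C(NCCNS(=O)(=O)c1cc(-c2ccccc2Oc2ccc(O)c(O)c2)cs1)Nc1cc(C(F)(F)F)cc(C(F)(F)F)c1`: limit only, > 50000 nM

Among the compounds with values here, in an ADME assay on HEK-293T cells (Homo sapiens) for cytotoxicity, read by CCK-8 assay, with a stated time of 48 h (a higher number here means a weaker inhibitor, a lower number a stronger inhibitor), compound 1 gives 12400 nM, and this is the only full number in the set. Compound 2 reaches only a limit of this assay, > 50000 nM, so no number stands behind it. Among the values shown, (the limit of > 50000 nM in this assay, at which 1 of the 2 values shown sits).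

Compound 3, `O=C(NCCNS(=O)(=O)c1ccc(-c2ccccc2O[C@H]2CC[C@H](O)CC2)s1)Nc1cc(Cl)cc(Cl)c1`, is not yet measured. It differs from compound 1 in one place: 4-hydroxycyclohexyl in place of 3,4-dihydroxyphenyl on an oxygen on an aromatic ring. Within the data shown here, no step between two measured compounds differing in one place is available, and compounds 1 and 2 differ in more than one place, so their two values show only that one is a number and the other a limit.

The step of a 1.6-fold higher number from compound 1 to compound 3 (0.21 log units; within the scatter) is expected to be small, toward weaker inhibition or none beyond the scatter. For compound 3 the estimate is 20000 nM, expected to fall between 8000 nM and 60000 nM.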

Compound 3, half-maximal inhibitory concentration: > 50000 nM
Compound 3: no number, only a limit; the forecaster's own chance of this, stated with the estimate: 30%; middle value at least 2.5-fold (0.39 log units) from the limit.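

In this assay, this position now has its first one-place comparison, with 4-hydroxycyclohexyl in place of 3,4-dihydroxyphenyl on the oxygen: an at least 4.0-fold higher number from compound 1 to compound 3 (0.60 log units; beyond the scatter). The step is beyond the scatter and is bounded on one side only. Compound 3 gives > 50000 nM, which is a limit and not a number, so the only full number in the series stays with the 3,4-dihydroxyphenyl group of compound 1, and the other values stand at the same limit: the limit of > 50000 nM in this assay, at which 2 of the 3 values shown sit.

As far as these compounds go, the true size of the step remains open, as does whether it follows from the loss of the aromatic ring or from the change in hydroxyl groups, since the two changes are joined in this one swap. Where a plain phenyl, or a cyclohexyl carrying an amine, would fall on the same oxygen in this assay also remains open.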